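From piperidin-1-yl to benzyl on compound 3

The source may hold more compounds than are shown below. What is called first, only, known or untested is meant among the compounds shown, and "the series" means these compounds.

Of the compounds shown here, three that share one core have numbers so far. In a functional assay on Caco-2 cells (Homo sapiens) for inhibition, read by MTT assay, with a stated time of 48 h, tested at 10 uM (on this read-out lower numbers stand for less inhibition of growth and higher numbers for more inhibition of growth at the one concentration tested), compound 1 `Cc1cc(=O)c2c(O)cc(OCc3ccc(Br)cc3)c([C@H]3CCN(C)C[C@H]3O)c2o1` gives 13% and compound 2 `CCN(CC)Cc1c(O)c([C@H]2CCN(C)C[C@H]2O)c2oc(C)cc(=O)c2c1O` gives 17% while compound 3 `Cc1cc(=O)c2c(O)c(CN3CCC(N4CCCCC4)CC3)c(O)c([C@H]3CCN(C)C[C@H]3O)c2o1` gives 31% as the highest of the three, beyond the scatter from both others. Compound 4 `Cc1cc(=O)c2c(O)c(CN3CCC(Cc4ccccc4)CC3)c(O)c([C@H]3CCN(C)C[C@H]3O)c2o1` departs from compound 3 in one place, with benzyl in place of piperidin-1-yl on a saturated ring carbon as the count of the change: benzyl in place of piperidin-1-yl on a saturated ring carbon. Among the compounds with values here, no measured pair shows this swap, and the three values give no direction for it, so no step beyond the scatter is expected in this assay here. The estimated move a number 1 percentage points lower from compound 3 to compound 4 (within the scatter) stays inside that scatter, though with little support. Compound 4 is expected at 30% within a range from 13% to 50% on this read-out.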

Compound 4, percent growth inhibition at one concentration: 21%
Compound 4: middle estimate off by 9 percentage points, on the high side, within the range that was stated.
By their numbers in this assay, from the lowest: compounds 1, 2, 4 and 3 (each within the scatter of the next, the first and the last beyond it).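

In this assay, within the data shown here, the swap of piperidin-1-yl for benzyl on this saturated ring carbon reads a number 10 percentage points lower from compound 3 to compound 4 (within the scatter), the first comparison of compounds that differ in one place. At this position, then, the two groups cannot be told apart, although the one that enters has a carbon-only aromatic ring and the one that leaves has a ring nitrogen. Nothing shown gives a reason for this step.

Open remains what a dimethylamino group, a hydroxyl or a longer chain such as phenethyl on this ring carbon would give in this assay.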